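This account rests on a few compounds, and the source may have more. Where it says the series, first, only, none or still open, it means among the compounds named here.

Measured so far: compound 1 `CCCCCCCC/C=C\CCCCCCCCOc1cc(O)c(C(C)=O)c(O)c1`, compound 2 `CCCCCCCCCCCCCCCCCCc1c(O)cc(O)c(C(C)=O)c1O` and compound 3 `CCCCCCCCCCCCCCCCCCOc1cc(O)c(C(C)=O)c(O)c1`. In a functional assay on HT-29 cells (Homo sapiens) for cytotoxicity, read by XTT assay, with a stated time of 72 h (on this read-out higher numbers stand for weaker inhibition and lower numbers for stronger inhibition), compound 1 gives 31000 nM. Compound 2 gives 28000 nM in this assay, a number within the scatter of compound 1. For compound 3 this assay reports only a limit, > 100000 nM.

The change dec-1-en-1-yl in place of decyl on a saturated chain carbon, eight bonds along the chain from an oxygen on an aromatic ring produced an at least 3.2-fold lower number from compound 3 to compound 1 (0.50 log units; beyond the scatter); its size is bounded by the limit of > 100000 nM in this assay, at which 1 of the 3 values shown sits. Compound 2 and compound 3 have the same atoms joined differently, and the difference between their cores is not broken down here.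

Compound 4 `CCCCCCCC/C=C\CCCCCCCCc1c(O)cc(O)c(C(C)=O)c1O` has not been measured. It arises from compound 2 through (dec-1-en-1-yl in place of decyl on a saturated chain carbon, eight bonds along the chain from an aromatic carbon). This is the same kind of change as that from compound 3 to compound 1, though not the same: there the place is on a saturated chain carbon, eight bonds along the chain from an oxygen on an aromatic ring, here on a saturated chain carbon, eight bonds along the chain from an aromatic carbon. Set beside an at least 3.2-fold lower number from compound 3 to compound 1 (0.50 log units; beyond the scatter), the expected step is a 1.9-fold lower number from compound 2 to compound 4 (0.27 log units; within the scatter), resting on that single precedent. For compound 4 the estimated value in this assay is 15000 nM, from 6000 nM to 40000 nM.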

Compound 4, half-maximal inhibitory concentration: > 100000 nM
Compound 4: a limit, no number; the forecaster's own chance of this, stated with the estimate: 5%; middle value at least 6.6-fold (0.82 log units) away from the limit.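

The same change gave an at least 3.5-fold higher number from compound 2 to compound 4 (0.55 log units; beyond the scatter), so the earlier result did not carry from one core to the other in this assay, and the two steps point in opposite directions: the same change on two cores in this assay, an at least 3.2-fold lower number (0.50 log units; beyond the scatter) from compound 3 to compound 1 and an at least 3.5-fold higher number (0.55 log units; beyond the scatter) from compound 2 to compound 4, at least 11-fold (1.06 log units) apart, beyond the scatter of two such steps. Neither step has a fixed size, as each rests on a value that is a limit and not a number: the limit of > 100000 nM in this assay, at which 2 of the 4 values shown sit. Among the compounds shown here, with only one pair on each core, this shows that the effect of dec-1-en-1-yl in place of decyl cannot be assumed to carry across these two cores, but it does not show which difference between the cores separates the results or how the change would behave on any other core.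

The compounds shown leave open whether a shorter chain, a longer chain, or a chain carrying an amine or a carboxylic acid would give steps of the same direction on both cores. They also leave open the actual values of compound 3 and compound 4, for which only limits are available.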